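The source may report more compounds than this note shows. Statements on the series, on what has been measured and on what is new or still open speak of the compounds shown alone.

In an ADME assay on microsomes from liver (Homo sapiens) for metabolic stability, read by LC-MS, tested at 1 uM (on this read-out higher numbers stand for fast clearance and lower numbers for slow clearance), compound 3 `N[C@H]1CC[C@@H](Oc2ccc([C@H]3CC[C@]4(CC3)OOC3(O4)C4CC5CC(C4)CC3C5)cc2)CC1` gives only a limit of the assay, not a number, at < 7 mL.min-1.g-1. Compound 1 `NCCCOc1ccc([C@H]2CC[C@]3(CC2)OOC2(O3)C3CC4CC(C3)CC2C4)cc1` also stops at a limit, < 7 mL.min-1.g-1. Compound 2 `c1cc([C@H]2CC[C@]3(CC2)OOC2(O3)C3CC4CC(C3)CC2C4)ccc1OC1CCNCC1` gives a true number, 15 mL.min-1.g-1. The set therefore leans on (the limit of < 7 mL.min-1.g-1 in this assay, at which 2 of the 3 values shown sit).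

Compound 4 `NCCCCOc1ccc([C@H]2CC[C@]3(CC2)OOC2(O3)C3CC4CC(C3)CC2C4)cc1` differs from compound 3 by 4-aminobutyl in place of 4-aminocyclohexyl on an oxygen on an aromatic ring.

The nearest measured swap, a step that the two limits leave unreadable from compound 1 to compound 3, gives no size to work with. The two readable steps, an at least 2.1-fold higher number from compound 1 to compound 2 (0.33 log units; beyond the scatter) and an at least 2.1-fold lower number from compound 2 to compound 3 (0.33 log units; beyond the scatter), both lie beyond the scatter, but both involve the piperidin-4-yl group of compound 2, which compound 4 lacks. Its 4-aminobutyl chain is closest to the 3-aminopropyl chain of compound 1, so no step beyond the scatter is expected in this assay, and a reading at or near the limit seems likely. The estimated change is a number no lower from compound 3 to compound 4 (the limit leaves the size open). For compound 4, the expected value is 7 mL.min-1.g-1, with an estimated range of 4 mL.min-1.g-1 to 15 mL.min-1.g-1.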

Compound 4, intrinsic clearance in microsomes: < 7 mL.min-1.g-1
Compound 4: a limit, no number; the forecaster's own chance of this, stated with the estimate: 55%; the middle value sits exactly at the limit.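

In this assay, compound 4 gives only a limit of the assay, < 7 mL.min-1.g-1, not a number. The steps from compound 1 and from compound 3 to this compound cannot be read, as both ends are limits, which leaves one step with a size: an at least 2.1-fold lower number from compound 2 to compound 4 (0.33 log units; beyond the scatter). A ring in this group is therefore not required for a reading at the limit, as the open 4-aminobutyl chain reaches it too, and the piperidin-4-yl group of compound 2 remains the only one shown with a true number: the limit of < 7 mL.min-1.g-1 in this assay, at which 3 of the 4 values shown sit.

Going by these compounds, how the true clearance of compound 1, compound 3 and compound 4 compares stays unknown, so neither chain length nor the cyclohexyl ring can be ranked. The compounds shown also leave open whether a dimethylamino group or a carboxylic acid in place of the amine on the butyl chain would give a true number.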